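Amide substituent change on the thiadiazole series

The source may report more compounds than this note shows. Statements on the series, on what has been measured and on what is new or still open speak of the compounds shown alone.

Compound 3 `CC(CSc1nnc(-c2ccncc2)s1)C(=O)Nc1c(Cl)cccc1Cl` is characterised in an ADME assay on BHK-21 cells (Mesocricetus auratus) for cytotoxicity, with a stated time of 3 days (on this read-out lower numbers stand for higher toxicity in this test and higher numbers for lower toxicity in this test), only by a limit: compound 3 gives > 50000 nM, which is a limit of the assay and not a number. Compound 1 `O=C(CCSc1nnc(-c2ccncc2)s1)Nc1c(Cl)cccc1Cl` lacks the methyl group of compound 3 and in this assay compound 1 gives 10300 nM. The step of an at least 4.8-fold higher number from compound 1 to compound 3 (0.68 log units; beyond the scatter) covers the methyl introduction. Compound 2 `CC(CSc1nnc(-c2ccncc2)s1)C(=O)NCc1ccccc1Cl` carries a 2-chlorobenzyl group on the amide-type nitrogen; in this assay compound 2 gives > 50000 nM, again a limit rather than a number. The step that the two limits leave unreadable from compound 2 to compound 3 therefore cannot be sized, as both values sit at the limit of > 50000 nM in this assay, at which 2 of the 3 values shown sit.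

Compound 4 `CC(CSc1nnc(-c2ccncc2)s1)C(=O)NCc1ccccc1` differs from compound 3 as follows: benzyl in place of 2,6-dichlorophenyl on an amide-type nitrogen. The step that bears on this change is a step that the two limits leave unreadable from compound 2 to compound 3, since it also swaps the group on the amide-type nitrogen; it is unreadable, yet both ends lie at the limit, so no step beyond the scatter in this assay is expected from the change. Compound 4 is therefore expected to remain at the limit as well, as an estimate 60000 nM with a range from 20000 nM to 200000 nM, which means an expected step that the limit leaves unreadable from compound 3 to compound 4 of no readable size.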

Compound 4, half-maximal cytotoxic concentration: > 50000 nM
Compound 4 gave a limit, no number; the forecaster's own chance of this, stated with the estimate: 75%; the middle value does not contradict the limit.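

In this assay compound 4 gives > 50000 nM, a limit and not a number. The steps linking compound 4 to compound 2 and compound 3 cannot be read: the limit of > 50000 nM in this assay, at which 3 of the 4 values shown sit.

From the compounds shown here alone, whether benzyl, 2-chlorobenzyl and 2,6-dichlorophenyl on the amide-type nitrogen differ at all in this assay remains open.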